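Aryl variation on the saturated ring carbon of the core

This account rests on a few compounds, and the source may have more. Where it says the series, first, only, none or still open, it means among the compounds named here.

Measured so far:
compound 1 `COc1cc(/C=C/C(=O)C2=C(/C=C/c3ccc(O)c(OC)c3)NC(=O)NC2c2ccccc2)ccc1O`: 50.2%
compound 2 `COc1cc(/C=C/C(=O)C2=C(/C=C/c3ccc(O)c(OC)c3)NC(=O)NC2c2ccc(C)cc2)ccc1O`: 52.2%

In a functional assay, with a stated time of 20 min, tested at 50 uM (on this read-out higher numbers stand for a stronger effect at the one concentration tested and lower numbers for a weaker effect), compound 1 gives 50.2% and compound 2 gives 52.2%. The one step known, a number 2 percentage points higher from compound 1 to compound 2 (within the scatter), does not separate the two, so compound 2 stands level with compound 1 on the numbers shown.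

Compound 3 `COc1cc(/C=C/C(=O)C2=C(/C=C/c3ccc(O)c(OC)c3)NC(=O)NC2c2ccccc2O)ccc1O` differs from compound 2 by 2-hydroxyphenyl in place of 4-methylphenyl on a saturated ring carbon. For the measured compounds named here, the only step measured concerns a methyl replacing hydrogen on that same aryl and stayed within the scatter; no step with a hydroxyl on this aryl is known. On that basis the expected step is a number 2.2 percentage points lower from compound 2 to compound 3 (within the scatter), none beyond the scatter. Compound 3 is estimated at 50%, range 38% to 62%.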

Compound 3, a percentage reported as activity, at one concentration (the size of the read-out at that concentration, not a potency): 88%
The estimate for compound 3 lay 38 percentage points below the measured number; measured number above the stated range.
By their numbers in this assay, from the lowest: compounds 1 and 2 (each within the scatter of the next); then compound 3.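

The aryl on the saturated ring carbon can move this read-out strongly: a hydroxyl added to that aryl gives a number 37.8 percentage points higher from compound 1 to compound 3 (beyond the scatter). Likewise, 2-hydroxyphenyl in place of 4-methylphenyl gives a number 35.8 percentage points higher from compound 2 to compound 3 (beyond the scatter), whereas the methyl step stayed within the scatter, so this position is not indifferent to every aryl change. Nothing at hand accounts for the gain.

Still open, from the compounds shown here alone, is whether 4-hydroxyphenyl would keep the gain, and whether 2-methoxyphenyl or 2-aminophenyl would match 2-hydroxyphenyl.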